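Working notes on cytotoxicity: fluoro to trifluoromethyl

The compounds below may be only part of what the source reports. "The series", "measured", "known", "first", "only" and "open" are said of these compounds alone.

Among the compounds with values here, the series so far holds two measured compounds. Compound 1 `Cc1ccc(-c2nn(-c3ccccc3)cc2-c2nc3ccccc3n2S(=O)(=O)c2ccc(C)cc2)cc1` gives 79300 nM in an ADME assay on HEK-293T cells (Homo sapiens) for cytotoxicity, read by MTT assay, with a stated time of 24 h; a lower number here means that less compound is tolerated, a higher number that more compound is tolerated. Compound 2 `Cc1ccc(-c2nn(-c3ccccc3)cc2-c2nc3ccccc3n2S(=O)(=O)c2ccc(F)cc2)cc1` gives 128000 nM in this assay. Within the data shown here, the one measured step, a 1.6-fold higher number from compound 1 to compound 2 (0.21 log units; within the scatter), shows that compound 2 and compound 1 are not separated by the numbers in hand; compound 2 stands at one of only two values, and the nearest, compound 1, lies within the scatter of it.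

Compound 3 `Cc1ccc(-c2nn(-c3ccccc3)cc2-c2nc3ccccc3n2S(=O)(=O)c2ccc(C(F)(F)F)cc2)cc1` differs from compound 2 by trifluoromethyl in place of fluoro on an aromatic carbon. Among the measured compounds shown here, the only step that bears on this change is the one at the same place, from compound 1 to compound 2, which was a 1.6-fold higher number from compound 1 to compound 2 (0.21 log units; within the scatter) and within the scatter. With a single reference step of that size and no other change at this position measured, no movement beyond the scatter is expected for compound 3 in this assay, in either direction, so the expected step is a 1.1-fold lower number from compound 2 to compound 3 (0.03 log units; within the scatter).

On that basis compound 3 is estimated at 120000 nM in this assay, with a range from 55000 nM to 260000 nM.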

Compound 3, half-maximal cytotoxic concentration: 182000 nM
Beside the measured number, compound 3's estimate is 1.5-fold (0.18 log units) below it; the measured number falls inside the stated range.
By their numbers in this assay, from the lowest: compounds 1, 2 and 3 (each within the scatter of the next, the first and the last beyond it).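

Working from the new data, trifluoromethyl in place of fluoro gives a 1.4-fold higher number from compound 2 to compound 3 (0.15 log units; within the scatter) in this assay, so these two groups are not separated at this position, and the 4-fluorophenyl to 4-(trifluoromethyl)phenyl change leaves the reading where the scatter cannot distinguish it. Within the data shown here, what the earlier compounds could not show is any separation at this position: trifluoromethyl in place of methyl gives a 2.3-fold higher number from compound 1 to compound 3 (0.36 log units; beyond the scatter), a modest step and the first beyond the scatter, while compound 2 stays within the scatter of both compound 1 and compound 3. Nothing available for these compounds accounts for that separation.

With only methyl, fluoro and trifluoromethyl shown at this position, it remains open whether a plain hydrogen, an amine, a carboxylic acid or a longer chain there would fall within the same narrow band of values or move clearly away from it. It also remains open whether the modest separation of trifluoromethyl from methyl would hold if the shared core were changed elsewhere, since every compound shown carries the same core.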